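This account rests on a few compounds, and the source may have more. Where it says the series, first, only, none or still open, it means among the compounds named here.

Measured compounds in a functional assay on HT-29 cells (Homo sapiens) for cytotoxicity, read by MTT assay, with a stated time of 72 h; a higher number here means a weaker inhibitor of growth, a lower number a stronger inhibitor of growth:

- compound 1, `CCCCC[Se]c1nc(N)c2cccnc2n1`, with 5910 nM
- compound 2, `CSc1nc(NCCCCc2ccccc2)c2ccccc2n1`, with > 100000 nM

Of the compounds shown here, two have been measured so far. In this assay compound 1 gives a number, 5910 nM. For compound 2 the assay reports no number but a limit, > 100000 nM. Compound 2 thus stands at the limit of > 100000 nM in this assay, at which 1 of the 2 values shown sits. Nothing connects the two structures by a single change, so the two values can only be set side by side: one a number, one a limit.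

The next compound, compound 3, `CSc1nc(NCCCCCO)c2ccccc2n1`, is made from compound 2 by one change: hydroxymethyl in place of phenyl on a saturated chain carbon, four bonds along the chain from a nitrogen on an aromatic ring. Among the compounds with values here, no step of this kind has been measured here, so the expectation rests on compound 2 alone, which sits at the limit. The step from compound 2 to compound 3 is expected to be a number no higher from compound 2 to compound 3 (the limit leaves the size open), that is, nothing beyond the usual scatter in either direction. Compound 3 is therefore expected to give about 100000 nM in this assay, with a range from 30000 nM to 300000 nM, and most likely the assay will again report only a limit rather than a number.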

Compound 3, concentration for 50% growth inhibition: > 100000 nM
Compound 3: only a limit was reported; the forecaster's own chance of this, stated with the estimate: 70%; the middle value sits exactly at the limit.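

In this assay, within the data shown here, compound 3, like compound 2, is reported only as a limit, so no step between the two can be read: the limit of > 100000 nM in this assay, at which 2 of the 3 values shown sit.

The compounds shown leave open whether phenyl and hydroxymethyl at this place differ at all in growth inhibition, and what separates either compound from compound 1.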